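The compounds below may be only part of what the source reports. "The series", "measured", "known", "first", "only" and "open" are said of these compounds alone.

Measured so far:
Compound 1, `CCCCOC(=O)Nc1cc2nc(C3CCCCC3)[nH]c2cc1N(CC)CCN(C)C`: > 100 ug/mL
Compound 2, `O=C(NCc1ccccc1)Nc1cc2nc(C3CCCCC3)[nH]c2cc1N1CCCC1`: > 100 ug/mL

In an ADME assay on Vero cells (Chlorocebus sabaeus) for cytotoxicity, read by resazurin assay, with a stated time of 3 days (a lower number here means a stronger inhibitor, a higher number a weaker inhibitor), compound 1 gives > 100 ug/mL, which is a limit of the assay and not a measured number. Compound 2 likewise gives > 100 ug/mL in this assay, again only a limit. Within the data shown here, compound 1 therefore stands at the limit of > 100 ug/mL in this assay, at which 2 of the 2 values shown sit; no number places it more precisely, and no step between measured compounds is available.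

Compound 3, `CCCCOC(=O)Nc1cc2nc(C3CCCCC3)[nH]c2cc1N(C)CCN(C)C`, has not yet been tested. It differs from compound 1 by hydrogen in place of methyl on a saturated chain carbon bound to a nitrogen on an aromatic ring. This is a small trimming of the chain on the nitrogen on the aromatic ring; the carbamate, the cyclohexyl group and the shared core stay the same. The step from compound 1 to compound 3 in this assay is expected to be a step that the limit leaves unreadable from compound 1 to compound 3, that is, none beyond the scatter. Compound 3 is expected to come out near 150 ug/mL, within 70 ug/mL to 400 ug/mL, most likely again as a limit.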

Compound 3, half-maximal inhibitory concentration: > 100 ug/mL
Compound 3: only a limit was reported (the forecaster's own chance of this, stated with the estimate: 85%); the middle value is on the limit's open side.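

In this assay compound 3 gives > 100 ug/mL, which is a limit and not a number. No step from compound 1 to compound 3 can be read, because both compounds sit at a limit: the limit of > 100 ug/mL in this assay, at which 3 of the 3 values shown sit.

The compounds shown leave open what concentration, if any, would prove toxic to these cells.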